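Thiophene for phenyl on a thiazolidinedione benzylidene series

This account rests on a few compounds, and the source may have more. Where it says the series, first, only, none or still open, it means among the compounds named here.

The compounds measured so far:
compound 1, `COc1ccc(/C=C2\SC(=O)N(Cc3ccc(C(=O)O)cc3)C2=O)cc1`, giving 44000 nM;
compound 2, `O=C(O)c1ccc(CN2C(=O)S/C(=C\c3ccccc3)C2=O)cc1`, giving 90000 nM;
compound 3, `COc1cc(/C=C2\SC(=O)N(Cc3ccc(C(=O)O)cc3)C2=O)cc(OC)c1OC`, giving 36000 nM.

All three were tested in a functional assay on A549 cells (Homo sapiens) for cytotoxicity, read by MTT assay, with a stated time of 24 h; on this read-out higher numbers stand for weaker inhibition and lower numbers for stronger inhibition. Compound 2 gives the highest number of the three; its nearest neighbour is compound 1, and its furthest is compound 3, which gives a lower number. Going by the values given here, the only single change measured is a 2.0-fold higher number from compound 1 to compound 2 (0.31 log units; beyond the scatter), and that change concerns a group on an aromatic carbon, not the ring itself.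

Compound 4, `O=C(O)c1ccc(CN2C(=O)S/C(=C\c3cccs3)C2=O)cc1`, differs from compound 2 by thiophen-2-yl in place of phenyl on a double-bonded chain carbon bound to a double-bonded ring carbon. Among the compounds with values here, no measured step in this set bears directly on swapping one aromatic ring for another, so compound 2 alone serves as the anchor. Given how close the three numbers already sit, the step from compound 2 to compound 4 is expected to be small, a 1.3-fold lower number from compound 2 to compound 4 (0.11 log units; within the scatter), and not clearly beyond the scatter. Compound 4 is therefore estimated at 70000 nM, within a range from 30000 nM to 160000 nM.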

Compound 4, half-maximal inhibitory concentration: 80000 nM
The estimate for compound 4 lay 1.1-fold (0.06 log units) below the measured number, within the range that was stated.
By their numbers in this assay, from the lowest: compounds 3, 1, 4 and 2 (each within the scatter of the next, the first and the last beyond it).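

In this assay, the chain carbon bound to a double-bonded ring carbon now shows its first exchange of one aromatic ring for another, and the step is small (from a 1.1-fold lower number from compound 2 to compound 4 (0.05 log units; within the scatter)), so thiophen-2-yl and phenyl cannot be told apart here. Thiophen-2-yl in place of 4-methoxyphenyl also stays inside the scatter (a 1.8-fold higher number from compound 1 to compound 4 (0.26 log units; within the scatter)), whereas hydrogen in place of methoxy on the phenyl ring lay just beyond it (a 2.0-fold higher number from compound 1 to compound 2 (0.31 log units; beyond the scatter)). No evidence accompanies these results to explain the numbers.

The compounds shown leave open whether a methoxy group on the thiophen-2-yl ring would move the number as it does on phenyl. They also leave open whether a furan-2-yl or pyridin-3-yl ring, or a ring carrying an amine, would stay within the same narrow band.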